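The compounds below may be only part of what the source reports. "The series", "measured", "known", "first", "only" and "open" are said of these compounds alone.

Compound 3, `O=C(O)Cc1sc(CSc2ccccc2)nc1-c1ccc(Cl)cc1`, is measured in an in vitro functional assay on HEK285-7 cells for antagonist activity at prostaglandin D2 receptor 2 (Homo sapiens), read by BRET and beta-arrestin recruitment (a higher number here means a larger maximal response, a lower number a smaller maximal response), where compound 3 gives 50%. On that number compound 3 stands level with compound 1, `Nc1nc(-c2ccc(Cl)cc2)c(CC(=O)O)s1`, which in this assay gives 50%, and with compound 2, `O=C(O)Cc1sc(COc2ccc(Cl)cc2)nc1-c1ccc(Cl)cc1`, which gives 50%. The two measured steps that lead to compound 3 are no change at the digits printed from compound 1 to compound 3 (within the scatter) and no change at the digits printed from compound 2 to compound 3 (within the scatter). Compound 4, `O=C(O)Cc1sc(NCc2ccccc2)nc1-c1ccc(Cl)cc1`, has not yet been measured; it differs from compound 3 by benzylamino in place of (phenylsulfanyl)methyl on an aromatic carbon. Both earlier steps also swapped one side group for another and left the maximal response unchanged, so no step beyond the scatter is expected here either. Compound 4 is therefore estimated to give 50%, within a range from 35% to 65%. The expected step is no change at the digits printed from compound 3 to compound 4 (within the scatter).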

Compound 4, largest response reached (reported as efficacy), in percent of the reference or control that the assay uses: 30%
Compound 4: middle estimate off by 20 percentage points, on the high side; measured number outside the range, below it.
By their numbers in this assay, from the lowest: compound 4; then compounds 1, 2 and 3 (each within the scatter of the next).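

Until now, changing the group at this position left the maximal response unmoved, but in this assay the result depends on how its phenyl ring is attached. Two groups of 8 heavy atoms each, differing in a sulfur-containing link and a nitrogen link, give a number 20 percentage points lower from compound 3 to compound 4 (beyond the scatter), and adding benzyl to the amino nitrogen gives a number 20 percentage points lower from compound 1 to compound 4 (beyond the scatter). No measurement available here explains this lower response.

As far as these compounds go, it remains open whether the lower response follows the nitrogen link itself or the hydrogen on it. A methyl group on that nitrogen, replacing its hydrogen, would separate these two readings.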